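A chloro swap on compound 2

The compounds below may be only part of what the source reports. "The series", "measured", "known", "first", "only" and "open" are said of these compounds alone.

In a functional assay on HCT-116 cells (Homo sapiens) for cytotoxicity, read by MTT assay (on this read-out higher numbers stand for weaker inhibition and lower numbers for stronger inhibition), compound 1 `Cc1cc(O)c(C(=O)/C=C/c2ccccc2)c(=O)o1` gives > 100000 nM as its reading, which is a limit of the assay and not a number. Compound 2 `Cc1cc(O)c(C(=O)/C=C/c2cccc(F)c2)c(=O)o1` gives 81200 nM and compound 3 `Cc1cc(O)c(C(=O)/C=C/c2ccc(F)c(F)c2)c(=O)o1` gives 74900 nM as readings within the scatter of each other. Compound 4 `Cc1cc(O)c(C(=O)/C=C/c2cccc(Cl)c2)c(=O)o1` differs from compound 2 by chloro in place of fluoro on an aromatic carbon and is still unmeasured. The closest measured changes, each fluoro in place of hydrogen on an aromatic carbon, are an at least 1.2-fold lower number from compound 1 to compound 2 (0.09 log units; that floor lies within the scatter) and a 1.1-fold lower number from compound 2 to compound 3 (0.04 log units; within the scatter) and neither goes beyond the scatter, though the first is only a floor. No step beyond the scatter is therefore expected in this assay for this swap. The expected change is a 1.2-fold lower number from compound 2 to compound 4 (0.10 log units; within the scatter) as an estimate. For compound 4 the estimated value is 65000 nM with an expected range from 30000 nM to 100000 nM as its bounds.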

Compound 4, half-maximal inhibitory concentration: 66400 nM
Estimate against measurement, compound 4: 1.0-fold (0.01 log units) below; the measured number falls inside the stated range.
By their numbers in this assay, from the lowest: compounds 4, 3 and 2 (each within the scatter of the next). At a limit, above all of these: compound 1.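

At this position, chloro in place of fluoro gives a 1.2-fold lower number from compound 2 to compound 4 (0.09 log units; within the scatter), so in this assay exchanging one halogen for the other leaves the reading within the scatter. Chloro in place of hydrogen gives an at least 1.5-fold lower number from compound 1 to compound 4 (0.17 log units; that floor lies within the scatter). That step is only a floor, as the reading for compound 1 is a limit: the limit of > 100000 nM in this assay, at which 1 of the 4 values shown sits.

Going by these compounds, whether a different kind of group at this position, such as an amine or a carboxylic acid, would move the reading beyond the scatter stays open. On these data alone, the true gap between compound 1 and compound 4 also stays open.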